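This account rests on a few compounds, and the source may have more. Where it says the series, first, only, none or still open, it means among the compounds named here.

Compound 3 `CCCN(CCC)c1cc(C)nc2c(-c3ncc(Cl)cc3C)c(C)nn12` stands at the lowest number among the three compounds measured in an assay on isolated protein for binding affinity to corticotropin-releasing factor receptor 1 (Homo sapiens); on this read-out lower numbers stand for stronger inhibition and higher numbers for weaker inhibition: compound 3 gives 6.7 nM, compound 2 `CCCN(CCC)c1cc(C)nc2c(-c3ncc(N4CCCCC4)cc3C)c(C)nn12` gives 17 nM, and compound 1 `CCCN(CCC)c1cc(C)nc2c(-c3ncc(NC)cc3C)c(C)nn12` gives 40 nM. Both steps down to compound 3 lie beyond the scatter, a 6.0-fold lower number from compound 1 to compound 3 (0.78 log units; beyond the scatter) and a 2.5-fold lower number from compound 2 to compound 3 (0.40 log units; beyond the scatter), as does the step of a 2.4-fold lower number from compound 1 to compound 2 (0.37 log units; beyond the scatter). Compound 4 `CCCN(CCC)c1cc(C)nc2c(-c3ncc(O)cc3C)c(C)nn12` differs from compound 3 in one place: hydroxy in place of chloro on an aromatic carbon. Within the data shown here, no measured step replaces chloro with hydroxy, so the expectation rests on the three groups already tried at that carbon. Among the measured compounds shown here, the only measured group carrying a hydrogen-bond donor, methylamino in compound 1, sits furthest from chloro in this assay, and hydroxy, which also brings a donor, is therefore expected to move the number back up rather than down. Compound 4 is expected to give 30 nM in this assay, within a range of 8 nM to 120 nM, that is an expected step of a 4.5-fold higher number from compound 3 to compound 4 (0.65 log units; beyond the scatter).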

Compound 4, inhibition constant: 530 nM
For compound 4 the middle estimate is 18-fold (1.25 log units) below the measured one, and the stated range ends below it.
By their numbers in this assay, from the lowest: compound 3; then compound 2; then compound 1; then compound 4.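

Hydroxy gives the highest number of the four groups at this carbon in this assay, and replacing chloro with it produces the largest step in the set (a 79-fold higher number from compound 3 to compound 4 (1.90 log units; beyond the scatter)), although one heavy atom simply replaces another. Hydroxy also lies well above the compounds carrying piperidin-1-yl (a 31-fold higher number from compound 2 to compound 4 (1.49 log units; beyond the scatter)) and methylamino (a 13-fold higher number from compound 1 to compound 4 (1.12 log units; beyond the scatter)), so a donor-bearing group at this carbon can cost far more than compound 1 alone suggested, and the bulkier piperidin-1-yl is tolerated much better than this small group. Nothing available explains why hydroxy behaves this way.

The compounds shown leave open whether methoxy, which caps the oxygen, would recover the lost ground. They also do not show how a primary amine, fluoro or a carboxylic acid would fall at this carbon.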